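The source may report more compounds than this note shows. Statements on the series, on what has been measured and on what is new or still open speak of the compounds shown alone.

In a functional assay on isolated protein for agonist activity at Glucose-dependent insulinotropic receptor (Rattus norvegicus), read by HTRF and cAMP accumulation (a lower number here means a smaller maximal response, a higher number a larger maximal response), compound 1 `CC(C)(C)OC(=O)N1CCC(O[C@H]2CC[C@@H](Oc3ccc(S(C)(=O)=O)cc3)CC2)CC1` gives 121% and compound 2 `CC(C)(C)OC(=O)N1CCC(O[C@H]2CC[C@H](Oc3ccc(S(C)(=O)=O)cc3F)CC2)CC1` gives 119%. Compound 3 `CS(=O)(=O)c1cnc(O[C@H]2CC[C@H](OC3CCN(C(=O)OC4CCOC4)CC3)CC2)cn1` gives 109% in this assay, the lowest of the three numbers; its gap to compound 2 lies within the scatter, while the gap to compound 1 lies beyond it. Compound 4 `CC(C)c1noc(CN2CCC(O[C@H]3CC[C@H](Oc4cnc(S(C)(=O)=O)cn4)CC3)CC2)n1` differs from compound 3 in one place: (3-isopropyl-1,2,4-oxadiazol-5-yl)methyl in place of ((oxolan-3-yl)oxy)carbonyl on an amine nitrogen in a ring. No step between measured compounds is available to weigh this change, and every number shown is a large maximal response, so compound 4 is expected to stay close, with the step of a number 3 percentage points higher from compound 3 to compound 4 (within the scatter) lying within the scatter. Compound 4 is therefore estimated at 112%, between 95% and 128%.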

Compound 4, largest response reached (Emax), in percent of the reference or control that the assay uses: 115%
Compound 4: the middle estimate sits 3 percentage points below what was measured; low and high end bracket the measured number.
By their numbers in this assay, from the lowest: compounds 3, 4, 2 and 1 (each within the scatter of the next, the first and the last beyond it).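

In this assay, putting (3-isopropyl-1,2,4-oxadiazol-5-yl)methyl in place of ((oxolan-3-yl)oxy)carbonyl on the amine nitrogen in a ring gives a number 6 percentage points higher from compound 3 to compound 4 (within the scatter) and so leaves the maximal response unchanged within the scatter. At this position, then, the large response does not depend on a carbonyl or on a non-aromatic five-membered ring, since a five-membered aromatic ring with three hetero atoms serves as well. Nothing measured here explains why the two groups match. Still open, on these data alone, is whether a much smaller substituent, such as a methyl group or the bare ring amine, would hold the response.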